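A few compounds are considered here, and "the series" means these few. Any claim that something is new, unique, unknown or untested is made for them only; others in the source may bear on it.

Measured so far in a functional assay on IMR-32 cells (Homo sapiens) for antiproliferative activity, read by MTT assay; on this read-out lower numbers stand for stronger inhibition and higher numbers for weaker inhibition:
compound 1 `CC1(C)CCc2cc(C(=O)/C=C/c3ccc(OCc4cn(-c5ccc(Cl)cc5)nn4)cc3)c(O)cc2O1` 92100 nM
compound 2 `CC1(C)CCc2cc(C(=O)/C=C/c3ccc(OCc4cn(-c5ccc(Br)cc5)nn4)cc3)c(O)cc2O1` 69400 nM
Not yet measured:
compound 3 `Cc1c(-n2cc(COc3ccc(/C=C/C(=O)c4cc5c(cc4O)OC(C)(C)CC5)cc3)nn2)cccc1[N+](=O)[O-]`

Compound 2 gives 69400 nM and lies within the scatter of compound 1 (92100 nM), so neither can be ranked above the other. Compound 3 carries 2-methyl-3-nitrophenyl in place of 4-bromophenyl on an aromatic nitrogen. Among the compounds with values here, only one measured step bears on this, a 1.3-fold lower number from compound 1 to compound 2 (0.12 log units; within the scatter), a bromo in place of a chloro on an aromatic carbon and within the scatter. That step exchanges a single halogen and leaves the rest of the aryl group untouched, so it is a weak guide to replacing the whole group. No shift beyond the scatter is therefore expected in this assay, though with wide uncertainty. The estimated step is a 1.1-fold lower number from compound 2 to compound 3 (0.03 log units; within the scatter), which is small. Compound 3 is estimated at 65000 nM, with an expected range from 22000 nM to 150000 nM.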

Compound 3, half-maximal inhibitory concentration: "not active" (no number reported)
Compound 3 has no reported number here, so the estimate cannot be set against anything.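

Within the data shown here, compound 3 is reported as "not active" in this assay with no number, so no step from compound 2 to compound 3 can be read. The compounds shown leave open how far 2-methyl-3-nitrophenyl in place of 4-bromophenyl moves the value, and no supporting data bear on this result.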